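Trimming a hydroxy from compound 3: expected cytotoxicity

The source may report more compounds than this note shows. Statements on the series, on what has been measured and on what is new or still open speak of the compounds shown alone.

Going by the values given here, compound 3 `Cc1cc(-c2c(F)cc3c(=O)c(Cc4c(O)cccc4O)cn(C4CC4)c3c2F)cc(C)n1` gives the lowest of the three numbers measured so far in a functional assay on P388 cells (Mus musculus) for cytotoxicity (on this read-out lower numbers stand for stronger inhibition and higher numbers for weaker inhibition), at 250 nM. Compound 1 `Cc1cc(-c2c(F)cc3c(=O)ccn(C4CC4)c3c2F)cc(C)n1` carries hydrogen where compound 3 carries the 2,6-dihydroxybenzyl group; in this assay compound 1 gives 15000 nM. Compound 2 `COc1cccc(Cc2cn(C3CC3)c3c(F)c(-c4cc(C)nc(C)c4)c(F)cc3c2=O)c1`, with 3-methoxybenzyl at that position, gives 20000 nM. The step of a 60-fold lower number from compound 1 to compound 3 (1.78 log units; beyond the scatter) and the step of an 80-fold lower number from compound 2 to compound 3 (1.90 log units; beyond the scatter) both accompany the introduction of the 2,6-dihydroxybenzyl group, whereas a 1.3-fold higher number from compound 1 to compound 2 (0.12 log units; within the scatter) shows that a 3-methoxybenzyl group on its own brings nothing beyond the scatter.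

Compound 4 `Cc1cc(-c2c(F)cc3c(=O)c(Cc4ccccc4O)cn(C4CC4)c3c2F)cc(C)n1` differs from compound 3 by hydrogen in place of hydroxy on an aromatic carbon. Among the compounds with values here, no measured step so far varies a hydroxy on that ring singly; the only evidence is that the dihydroxy pattern as a whole separates compound 3 from compounds 1 and 2 by a large margin. Part of that margin is expected to be lost, not all of it; the other hydroxy and the benzyl group stay in place. A moderate upward step is therefore expected, a 6.0-fold higher number from compound 3 to compound 4 (0.78 log units; beyond the scatter). Compound 4 is estimated at 1500 nM in this assay, with a range from 400 nM to 6000 nM.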

Compound 4, half-maximal inhibitory concentration: 670 nM
Compound 4: the middle estimate sits 2.2-fold (0.35 log units) above what was measured, and the stated range covers the measured number.
By their numbers in this assay, from the lowest: compound 3; then compound 4; then compounds 1 and 2 (each within the scatter of the next).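

In this assay, a 2.7-fold higher number from compound 3 to compound 4 (0.43 log units; beyond the scatter) follows the loss of a single hydroxy, so this change on the ring costs only a modest part of the large margin held by compound 3 over the compounds without a hydroxy. The 2-hydroxybenzyl group alone keeps most of that margin, with a 22-fold lower number from compound 1 to compound 4 (1.35 log units; beyond the scatter) on replacing hydrogen and a 30-fold lower number from compound 2 to compound 4 (1.47 log units; beyond the scatter) on exchanging the 3-methoxyphenyl for the 2-hydroxyphenyl, so the second hydroxy of the 2,6-dihydroxybenzyl group is not needed for a large step at this position. No independent evidence bears on what lies behind these steps.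

Compound 2 and compound 4 differ both in the group on the ring and in where it sits, so the series leaves open whether the hydroxy itself or its place on the ring separates them. Also open, as far as these compounds go, is how this assay responds when an amine or a carboxylic acid stands in place of the remaining hydroxy, or when a longer chain joins this ring to the core.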